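Replacing a Phenyl with Cyclopropyl on the Shared Core

The source may report more compounds than this note shows. Statements on the series, on what has been measured and on what is new or still open speak of the compounds shown alone.

Among the compounds with values here, in an assay on membranes from HEK293 cells for displacement of a labelled ligand from Type-2 angiotensin II receptor (Homo sapiens), read by radioligand binding (a lower number here means a stronger inhibitor, a higher number a weaker inhibitor), compound 1 `CCCCOC(=O)NS(=O)(=O)c1ccc(CCC)cc1-c1ccc(Cn2c(-c3ccccc3)nc3ccccc32)cc1` gives 590 nM, the higher of the two numbers measured so far. Within the data shown here, compound 2 `CCCCOC(=O)NS(=O)(=O)c1ccc(CCC)cc1-c1ccc(Cn2c(C(C)(C)C)nc3ccccc32)cc1` gives 5.3 nM in this assay, and the single measured step, a 110-fold lower number from compound 1 to compound 2 (2.05 log units; beyond the scatter), shows tert-butyl in place of phenyl on an aromatic carbon. Compound 3 `CCCCOC(=O)NS(=O)(=O)c1ccc(CCC)cc1-c1ccc(Cn2c(C3CC3)nc3ccccc32)cc1` carries a related change: cyclopropyl in place of phenyl on an aromatic carbon. Among the measured compounds shown here, only that one step bears on it, and it was large, so a sizeable drop is expected, though perhaps not the full extent seen with tert-butyl. For compound 3 the estimated step is a 30-fold lower number from compound 1 to compound 3 (1.47 log units; beyond the scatter), giving an expected value of 20 nM with a range from 4 nM to 100 nM.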

Compound 3, inhibition constant: 31 nM
Compound 3: the middle estimate sits 1.6-fold (0.19 log units) below what was measured, and the stated range covers the measured number.
By their numbers in this assay, from the lowest: compound 2; then compound 3; then compound 1.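

Here a 19-fold lower number from compound 1 to compound 3 (1.28 log units; beyond the scatter) shows that in this assay the gain over phenyl at this position is not confined to tert-butyl, since cyclopropyl, with its three-membered non-aromatic ring, also delivers it. Cyclopropyl does not reach tert-butyl, however, and a 5.8-fold higher number from compound 2 to compound 3 (0.77 log units; beyond the scatter) separates the two groups on the same core. No evidence given here accounts for either step. From the compounds shown here alone, how isopropyl or cyclobutyl would compare at this position remains open, as does the effect of an amine or a longer chain such as n-butyl.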